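Working notes: cytotoxicity of compounds 1 to 4

A few compounds are considered here, and "the series" means these few. Any claim that something is new, unique, unknown or untested is made for them only; others in the source may bear on it.

Measured so far in a functional assay on MT2 cells (Homo sapiens) for cytotoxicity, read by MTT assay; a higher number here means that more compound is tolerated, a lower number that less compound is tolerated:
compound 1 `COc1ccc(Nc2nccs2)cc1OCC=C(C)C` gives 42000 nM
compound 2 `CC(C)=CCOc1cc(Nc2nccs2)ccc1Cl` gives 26000 nM
compound 3 `CC(C)=CCOc1cc(Nc2nc(N)cc(Cl)n2)ccc1Cl` gives 14 nM

Compound 2 and compound 1 differ in one place, (methoxy in place of chloro on an aromatic carbon), and the step is a 1.6-fold higher number from compound 2 to compound 1 (0.21 log units; within the scatter). The two values therefore cannot be set in order against each other.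

Compound 3 gives the lowest number of the three, and its gaps to compound 2 and to compound 1 lie beyond the scatter, so among the measured compounds it is the one of which the cells tolerate least. The difference between the core of compound 3 and the core of compound 2 is not broken down here.

Compound 4 `COc1cc(N)nc(Nc2ccc(Cl)c(OCC=C(C)C)c2)n1` has not yet been measured. It differs from compound 3 by methoxy in place of chloro on an aromatic carbon. Among the measured compounds shown here, this is the same kind of change as the one from compound 2 to compound 1, but not the same: there the group sat on a six-membered aromatic ring of carbon only, ortho to a (3-methylbut-2-en-1-yl)oxy group and para to a (1,3-thiazol-2-yl)amino group; here it sits on a six-membered aromatic ring with 2 nitrogen, next to the ring nitrogen, meta to a large group, meta to an amino group, opposite the ring nitrogen.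

A step of a 1.4-fold higher number from compound 3 to compound 4 (0.15 log units; within the scatter) is expected from compound 3 to compound 4, a small one, because a 1.6-fold higher number from compound 2 to compound 1 (0.21 log units; within the scatter) lay within the scatter; the different surroundings of the place leave the range wide. Compound 4 is thus estimated at 20 nM, between 6 nM and 70 nM.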

Compound 4, half-maximal cytotoxic concentration: 19000 nM
Beside the measured number, compound 4's estimate is 950-fold (2.98 log units) below it; the whole stated range lies below it.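

In this assay, methoxy in place of chloro on the six-membered aromatic ring with 2 nitrogen gives a 1400-fold higher number from compound 3 to compound 4 (3.13 log units; beyond the scatter), so the cells tolerate far more of the methoxy member of this pair. The same change does not carry a fixed step from one core to the other in this series: the same change on two cores in this assay, a 1.6-fold higher number (0.21 log units; within the scatter) from compound 2 to compound 1 and a 1400-fold higher number (3.13 log units; beyond the scatter) from compound 3 to compound 4, 840-fold (2.92 log units) apart, beyond the scatter of two such steps This shows that the step seen on one core could not be carried over to the other, but it does not show which feature of the cores sets the difference, as the two pairs differ in both the core and the surroundings of the place, and two pairs give no rule for further cores.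

As far as these compounds go, it remains open whether the low number of compound 3 depends specifically on chloro at this place, or whether bromo, methyl or an amine there would give a number close to that of compound 3 or close to that of compound 4. Also open, from the compounds shown here alone, is whether a step of this size would persist if the (3-methylbut-2-en-1-yl)oxy group gave way to a shorter chain such as ethoxy.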